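This account rests on a few compounds, and the source may have more. Where it says the series, first, only, none or still open, it means among the compounds named here.

Series notes. Compound 3 `CCCCNC1=CC(=O)C=C(C[C@]2(C)[C@@H](C)CC[C@]3(C)C(C)=CCC[C@@H]23)C1=O` and compound 1 `CCCCCCCCNC1=CC(=O)C=C(C[C@]2(C)[C@@H](C)CC[C@]3(C)C(C)=CCC[C@@H]23)C1=O` share one core; compound 2 `CCCCNC1=CC(=O)C(C(C)(C)C)=CC1=O` and compound 4 `CCCCCCCCNC1=CC(=O)C(C(C)(C)C)=CC1=O` share another, and how the two cores differ is not broken down here. In a functional assay on NCI-H460 cells (Homo sapiens) for cytotoxicity, read by MTT assay, with a stated time of 72 h (on this read-out lower numbers stand for stronger inhibition and higher numbers for weaker inhibition), compound 3 gives 6000 nM, while compound 1 gives 35000 nM. The change between them, (butyl in place of hydrogen on a saturated chain carbon, four bonds along the chain from an amine nitrogen), produced a 5.8-fold higher number from compound 3 to compound 1 (0.77 log units; beyond the scatter). In this assay compound 2 gives 72000 nM, the highest number of the three measured compounds, beyond the scatter from compound 1 and further still from compound 3.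

Compound 4 is not yet measured in this assay; it differs from compound 2 by butyl in place of hydrogen on a saturated chain carbon, four bonds along the chain from an amine nitrogen, the same change at the same place as from compound 3 to compound 1. That step has been seen only once, on a different core, so its transfer rests on a single observation and on nothing about the core of compound 2 itself. If the change carries over, compound 4 is expected to give 250000 nM in this assay, a step of a 3.5-fold higher number from compound 2 to compound 4 (0.54 log units; beyond the scatter) that follows the earlier one because of a 5.8-fold higher number from compound 3 to compound 1 (0.77 log units; beyond the scatter). Given that compound 2 already sits at 72000 nM, compound 4 would then be expected to be a weak inhibitor in this assay, and the actual number is uncertain at this end of the range. For compound 4 the expected range is 70000 nM to 700000 nM.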

Compound 4, half-maximal inhibitory concentration: 65000 nM
Estimate against measurement, compound 4: 3.8-fold (0.59 log units) above, and the stated range ends above it.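

In this assay, the same change of hydrogen to butyl on the second core gives a 1.1-fold lower number from compound 2 to compound 4 (0.04 log units; within the scatter), so the rise in the number seen on the first core does not recur here. Set beside the earlier step, the change does not carry over unaltered from one core to the other in this series: the same change on two cores in this assay, a 5.8-fold higher number (0.77 log units; beyond the scatter) from compound 3 to compound 1 and a 1.1-fold lower number (0.04 log units; within the scatter) from compound 2 to compound 4, 6.5-fold (0.81 log units) apart, beyond the scatter of two such steps. This shows that a step measured on one of these cores cannot be taken as a guide to the other, but it rests on a single pair per core and does not show which difference between the cores accounts for the gap, or whether either step would hold for other chains.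

Going by these compounds, whether a longer chain at the same place, or an amine or a carboxylic acid at the end of the chain, would behave alike on the two cores remains open. Also open, on these data alone, is whether a third core would follow the step from compound 3 to compound 1, the step from compound 2 to compound 4, or neither.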